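Removing Trifluoromethyl in a T-type Calcium Channel Series

The source may hold more compounds than are shown below. What is called first, only, known or untested is meant among the compounds shown, and "the series" means these compounds.

Measured so far, in an assay on cells for inhibition of Voltage-dependent T-type calcium channel subunit alpha-1H (Homo sapiens), read by FLIPR and calcium flux, with stated times of 600 s and 300 s; on this read-out lower numbers stand for stronger inhibition and higher numbers for weaker inhibition:
Compound 1 `CN(Cc1ccc(OCCCNC(=N)N)cc1)c1nc2ccc(Oc3ccccc3)cc2s1`: compound 1 gives 498000 nM.
Compound 2 `CN(Cc1ccc(OCCCNC(=N)N)cc1)c1nc2ccc(Oc3cccc(C(F)(F)F)c3)cc2s1`: compound 2 gives 771000 nM.
Compound 3 `NCCCOc1ccc(CNc2nc3ccc(Oc4cccc(C(F)(F)F)c4)cc3s2)cc1`: compound 3 gives 171000 nM.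

Compound 1 and compound 2 share one core and differ in a single place: hydrogen in place of trifluoromethyl on an aromatic carbon. That change made a step of a 1.5-fold lower number from compound 2 to compound 1 (0.19 log units; within the scatter), so on this evidence the trifluoromethyl group carries little weight here. Compound 3 is built on a different core; the difference between the two cores is not broken down here. Its number is the lowest of the three, and both gaps to compound 1 and to compound 2 lie beyond the scatter.

Compound 4 `NCCCOc1ccc(CNc2nc3ccc(Oc4ccccc4)cc3s2)cc1` has not yet been measured. It is compound 3 with the same change applied: hydrogen in place of trifluoromethyl on an aromatic carbon. Since the place of the change is the same in both pairs, the expectation for compound 4 rests on the step from compound 2 to compound 1. The step from compound 3 to compound 4 is therefore expected to be small, about a 1.4-fold lower number from compound 3 to compound 4 (0.15 log units; within the scatter), because the earlier step was a 1.5-fold lower number from compound 2 to compound 1 (0.19 log units; within the scatter). Compound 4 is thus estimated at 120000 nM, with a likely range from 50000 nM to 300000 nM.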

Compound 4, half-maximal inhibitory concentration: > 1000000 nM
Compound 4: only a limit was reported (the forecaster's own chance of this, stated with the estimate: 15%); middle value at least 8.3-fold (0.92 log units) from the limit.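

In this assay compound 4 gives > 1000000 nM, which is a limit of the assay and not a number. Even so, the step can be read as an at least 5.8-fold higher number from compound 3 to compound 4 (0.76 log units; beyond the scatter), so the same swap of trifluoromethyl for hydrogen did not carry over from one core to the other: the same change on two cores in this assay, a 1.5-fold lower number (0.19 log units; within the scatter) from compound 2 to compound 1 and an at least 5.8-fold higher number (0.76 log units; beyond the scatter) from compound 3 to compound 4, at least 9.0-fold (0.95 log units) apart, beyond the scatter of two such steps This shows that the result on the core of compound 1 was a poor guide for the core of compound 3, but it rests on only two pairs, does not give the full size of the new step, and does not show which part of the difference between the cores matters.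

The compounds shown leave open whether a chlorine atom or a methyl group in place of trifluoromethyl would keep the number near that of compound 3. They also leave open how compound 3 would read with a guanidine in place of its amine, with the rest of the structure kept.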